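Thiophene for furan on the saturated ring carbon

This account rests on a few compounds, and the source may have more. Where it says the series, first, only, none or still open, it means among the compounds named here.

Compound 3 `CC1=C(C(=O)OCC2CCC2)C(c2ccoc2)NC(=O)N1` gives 2% in an assay on membranes from HeLa cells for displacement of a labelled ligand from adenosine receptor A3 (Homo sapiens), read by scintillation counting, with a stated time of 180 min, tested at 1 uM; a lower number here means less inhibition, a higher number more inhibition at the concentration tested (going by the name of the read-out). Two related compounds were also measured: compound 1 `CC1=C(C(=O)OC(C)(C)C)C(c2cccs2)NC(=O)N1` gives 7%, and compound 2 `CC1=C(C(=O)OCc2ccccc2)C(c2cccs2)NC(=O)N1` gives 8%. All three numbers lie within the scatter of one another, so none of them can be set apart from the rest; compound 3 simply sits at the low end of a narrow, low cluster.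

The unmeasured compound 4 `CC1=C(C(=O)OCC2CCC2)C(c2cccs2)NC(=O)N1` arises from compound 3 by one change: thiophen-2-yl in place of furan-3-yl on a saturated ring carbon. Within the data shown here, the only measured step between two compounds differing in one place is a number 1 percentage points higher from compound 1 to compound 2 (within the scatter), which concerns the ester group rather than the aromatic ring and so does not bear directly on this change. What the data do offer is that compounds 1 and 2, which already carry thiophen-2-yl on that carbon, sit at the same low level as compound 3.

On that basis compound 4 is expected to stay within the cluster, with a step of a number 4 percentage points higher from compound 3 to compound 4 (within the scatter) that is not beyond the scatter. Compound 4 is therefore estimated at 6%, within a range from 0% to 16%.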

Compound 4, a percentage reported as inhibition, at one concentration (the size of the read-out at that concentration, not a potency): 1%
Compound 4: the middle estimate sits 5 percentage points above what was measured; measured number inside the range.
By their numbers in this assay, from the lowest: compounds 4, 3, 1 and 2 (each within the scatter of the next).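

In this assay, the exchange on the saturated ring carbon now has a direct reading: with the cyclobutylmethyl ester held fixed, thiophen-2-yl in place of furan-3-yl gives a number 1 percentage points lower from compound 3 to compound 4 (within the scatter) and so does not separate the two rings. With thiophen-2-yl held fixed, the ester place reads the same way, with cyclobutyl in place of phenyl giving a number 7 percentage points lower from compound 2 to compound 4 (within the scatter) and cyclobutylmethyl in place of tert-butyl giving a number 6 percentage points lower from compound 1 to compound 4 (within the scatter) as the two further steps, so neither place moves the number out of the narrow, low cluster formed by these four compounds. No measurement at hand gives a reason for this flat reading.

All four compounds were read at one concentration and sit close together, so these numbers give no ranking of the groups and no potency for any of them. As far as these compounds go, it stays open whether a pyridine ring on the saturated ring carbon, or an amide in place of the ester, would lift the inhibition clear of this cluster.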